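Longer isothiocyanate chain on the fluorinated amide

The compounds below may be only part of what the source reports. "The series", "measured", "known", "first", "only" and "open" are said of these compounds alone.

For the measured compounds named here, compound 3 `CN(C)C(=O)c1cc2cnc(Nc3ccc(C(=O)NCCCCN=C=S)cc3F)nc2n1C1CCCC1` gives -7% in a functional assay on A549 cells (Homo sapiens) for inhibition, read by CCK-8 assay, with a stated time of 72 h, tested at 1 uM (a higher number here means a stronger effect of the compound at the concentration tested, a lower number a weaker effect), the lowest of the three numbers measured so far. Nearest to it stands compound 2 `CN(C)C(=O)c1cc2cnc(Nc3ccc(C(=O)NCCCN=C=S)cc3F)nc2n1C1CCCC1` with 16.7%, and furthest compound 1 `CN(C)C(=O)c1cc2cnc(Nc3ccc(C(=O)NCCCCN=C=S)cc3)nc2n1C1CCCC1` with 30.2%; both gaps lie beyond the scatter. The two steps leading into compound 3 are a number 37.2 percentage points lower from compound 1 to compound 3 (beyond the scatter) and a number 23.7 percentage points lower from compound 2 to compound 3 (beyond the scatter), the first large, the second modest.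

Compound 4 `CN(C)C(=O)c1cc2cnc(Nc3ccc(C(=O)NCCCCCCCN=C=S)cc3F)nc2n1C1CCCC1` differs from compound 3 by a group of 6 heavy atoms (4 carbon, 1 nitrogen, 1 sulfur; no ring) in place of a group of 3 heavy atoms (1 carbon, 1 nitrogen, 1 sulfur; no ring), on a saturated chain carbon, four bonds along the chain from an amide-type nitrogen. Going by the values given here, only one measured step bears on this kind of change, the lengthening of the chain toward the isothiocyanate, a number 23.7 percentage points lower from compound 2 to compound 3 (beyond the scatter). That step pointed downward, but it is a single observation, and compound 3 already sits close to zero inhibition, so there is little room for a further fall of similar size. The balance of what is known points to a small downward step at most, likely within the scatter.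

For compound 4 the value in this assay is estimated at -5%, with a range from -25% to 15%. This corresponds to an expected step of a number 2 percentage points higher from compound 3 to compound 4 (within the scatter), not beyond the scatter.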

Compound 4, a percentage reported as inhibition, at one concentration (the size of the read-out at that concentration, not a potency): 0.05%
For compound 4 the middle estimate is 5.1 percentage points below the measured one, within the range that was stated.
By their numbers in this assay, from the lowest: compounds 3 and 4 (each within the scatter of the next); then compound 2; then compound 1.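

In this assay a further lengthening of the chain on the fluorinated amide gives a number 7.1 percentage points higher from compound 3 to compound 4 (within the scatter) and so does not separate the two longer chains at this position, four bonds along the chain from an amide-type nitrogen. Measured against the shorter chain the result is a number 16.7 percentage points lower from compound 2 to compound 4 (beyond the scatter) and confirms that, with the fluoro group in place, both longer chains read below compound 2 at the single concentration tested, so the earlier fall on lengthening is not a one-compound reading, while the readings of the two longer chains lie near zero and offer no further gradient. No measured information here explains this dependence on chain length.

The compounds shown leave open whether a chain as long as that of compound 4 would hold the reading of compound 1 at 30.2% on the amide without the fluoro group, since the chain length and the fluoro group have been compared only one at a time. They also leave open whether a shorter chain than any here, or an amine or a carboxylic acid in place of the isothiocyanate at the chain end, would give a reading clearly above zero in this assay at this concentration.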